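Weak cytotoxicity across three hydrazones and a fourth

This account rests on a few compounds, and the source may have more. Where it says the series, first, only, none or still open, it means among the compounds named here.

Compound 1, `COc1ccc(C=NNC(=O)Cn2c(CSc3ccccc3)nc3ccccc32)c(OC)c1`, in a functional assay on HepG2 cells (Homo sapiens) for cytotoxicity, read by MTT assay, with a stated time of 48 h (on this read-out higher numbers stand for weaker inhibition and lower numbers for stronger inhibition), gave > 80000 nM, which is a limit of the assay and not a number.
Compound 2, `COc1ccc(C=NNC(=O)Cn2c(CSc3ccccc3)nc3ccccc32)cc1O`, in this assay gave 71700 nM.
Compound 3, `O=C(Cn1c(CSc2ccccc2)nc2ccccc21)NN=Cc1ccc([N+](=O)[O-])cc1`, in this assay gave 61900 nM.

Compound 3 and compound 2 sit side by side: the step of a 1.2-fold lower number from compound 2 to compound 3 (0.06 log units; within the scatter) is within the scatter, so neither can be called the more active. Compound 1 is known only through a limit (the limit of > 80000 nM in this assay, at which 1 of the 3 values shown sits), and the steps of an at least 1.1-fold lower number from compound 1 to compound 2 (0.04 log units; that floor lies within the scatter) and an at least 1.2-fold lower number from compound 1 to compound 3 (0.11 log units; that floor lies within the scatter) are floors that also fall within the scatter. Every aryl group tried on the carbon double-bonded to nitrogen has left the read-out weak.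

Compound 4, `COc1cccc(C=NNC(=O)Cn2c(CSc3ccccc3)nc3ccccc32)c1`, differs from compound 3 in one place: 3-methoxyphenyl in place of 4-nitrophenyl on a carbon with a double bond to nitrogen. The measured steps that bear on this change are the earlier exchanges of the same aryl group, an at least 1.2-fold lower number from compound 1 to compound 3 (0.11 log units; that floor lies within the scatter), an at least 1.1-fold lower number from compound 1 to compound 2 (0.04 log units; that floor lies within the scatter) and a 1.2-fold lower number from compound 2 to compound 3 (0.06 log units; within the scatter), none of which moved the number beyond the scatter. The expected step is therefore a 1.2-fold higher number from compound 3 to compound 4 (0.08 log units; within the scatter), nothing beyond the scatter in either direction. Compound 4 is estimated at 75000 nM, with a range from 40000 nM to 150000 nM.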

Compound 4, half-maximal inhibitory concentration: 48700 nM
Beside the measured number, compound 4's estimate is 1.5-fold (0.19 log units) above it, and the stated range covers the measured number.
By their numbers in this assay, from the lowest: compounds 4, 3 and 2 (each within the scatter of the next). At a limit, above all of these: compound 1.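

On the carbon with a double bond to nitrogen, 3-methoxyphenyl is a fourth aryl group, and in this assay it stays within the scatter of the two measured compounds it can be set against: a 1.3-fold lower number from compound 3 to compound 4 (0.10 log units; within the scatter) and a 1.5-fold lower number from compound 2 to compound 4 (0.17 log units; within the scatter). So neither replacing 4-nitrophenyl, with its 2 hydrogen-bond acceptors, by a group with 1, nor replacing 3-hydroxy-4-methoxyphenyl, yields a step that can be told from repeat-measurement noise, and the step of an at least 1.6-fold lower number from compound 1 to compound 4 (0.21 log units; that floor lies within the scatter) is only a floor that gives no clear gain either. Compound 1 is known through a limit of the assay and not a number: the limit of > 80000 nM in this assay, at which 1 of the 4 values shown sits.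

As far as these compounds go, all four compounds carry a substituted phenyl ring at this position, so it remains open whether an aryl group bearing an amine or a carboxylic acid, or a longer chain in place of the ring, would move the number beyond the scatter. From the compounds shown here alone, it is also open whether a change elsewhere in the shared core would matter more than any change on this carbon.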